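Solubility of Compound 1 and an Isopropyl Analogue

A few compounds are considered here, and "the series" means these few. Any claim that something is new, unique, unknown or untested is made for them only; others in the source may bear on it.

compound 1 `CCN(CC)CCNc1n[n+]([O-])c2ccc(C)cc2[n+]1[O-]` > 49000000 nM
compound 2 `Cc1ccc2c(c1)[n+]([O-])c(NCCN1CCCCC1)n[n+]2[O-]` 45000000 nM
compound 3 `Cc1ccc2c(c1)[n+]([O-])c(NCCN1C(C)CCCC1C)n[n+]2[O-]` 48000000 nM

In a physicochemical assay for solubility, in the presence of a further agent that is not named here (a lower number here means a less soluble compound, a higher number a more soluble compound), compound 1 gives > 49000000 nM, which is a limit of the assay and not a number (the limit of > 49000000 nM in this assay, at which 1 of the 3 values shown sits). Compound 2 gives 45000000 nM and compound 3 gives 48000000 nM. The steps of an at least 1.0-fold lower number from compound 1 to compound 2 (0.03 log units; that floor lies within the scatter), an at least 1.0-fold lower number from compound 1 to compound 3 (0.00 log units; that floor lies within the scatter) and a 1.1-fold higher number from compound 2 to compound 3 (0.03 log units; within the scatter) all lie within the scatter, and each of them alters only the amine on the saturated chain. Compound 4 `CCN(CC)CCNc1n[n+]([O-])c2ccc(C(C)C)cc2[n+]1[O-]` differs from compound 1 at another place: isopropyl in place of methyl on an aromatic carbon. For the measured compounds named here, none of the measured steps touches the aromatic carbon, so none bears on this change and no direction can be read from them. A step within the scatter is therefore expected, an at least 1.2-fold lower number from compound 1 to compound 4 (0.08 log units; that floor lies within the scatter). Compound 4 is estimated at 40000000 nM, within a range from 15000000 nM to 49000000 nM.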

Compound 4, solubility: 45000000 nM
For compound 4 the middle estimate is 1.1-fold (0.05 log units) below the measured one, and the stated range covers the measured number.
By their numbers in this assay, from the lowest: compounds 2, 4 and 3 (each within the scatter of the next). At a limit, above all of these: compound 1.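

In this assay, for the compounds shown here, the earlier steps altered only the amine on the saturated chain, whereas this one shows the aromatic carbon taking isopropyl in place of methyl, with an at least 1.0-fold lower number from compound 1 to compound 4 (0.03 log units; that floor lies within the scatter) as the step. Compound 1 stands at a limit of the assay, not at a number: the limit of > 49000000 nM in this assay, at which 1 of the 4 values shown sits. On these data alone, the true size of the step therefore stays unknown.

As far as these compounds go, whether a carboxylic acid, an amine or a longer chain on this aromatic carbon would give a step beyond the scatter remains open. Also open, from the compounds shown here alone, is how isopropyl fares with piperidin-1-yl or 2,6-dimethylpiperidin-1-yl on the chain.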